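The compounds below may be only part of what the source reports. "The series", "measured", "known", "first", "only" and "open" are said of these compounds alone.

Three compounds sharing one core and differing only in the aryl group carried on the aromatic nitrogen have been measured in a functional assay on HepG2 cells (Homo sapiens) for inhibition, read by MTT assay, with a stated time of 72 h; on this read-out lower numbers stand for stronger inhibition and higher numbers for weaker inhibition. Compound 1 `COc1cccc(-n2cc(COc3cccc(NC(=O)Nc4ccc(Cl)c(C(F)(F)F)c4)c3)nn2)c1` gives 1310 nM in this assay, compound 2 `CC(C)c1cccc(-n2cc(COc3cccc(NC(=O)Nc4ccc(Cl)c(C(F)(F)F)c4)c3)nn2)c1` gives 3250 nM, and compound 3 `O=C(Nc1cccc(OCc2cn(-c3ccccc3Cl)nn2)c1)Nc1ccc(Cl)c(C(F)(F)F)c1` gives 1960 nM. For the measured compounds named here, compound 3 stands second highest of the three numbers: the step of a 1.5-fold higher number from compound 1 to compound 3 (0.17 log units; within the scatter) and the step of a 1.7-fold lower number from compound 2 to compound 3 (0.22 log units; within the scatter) both lie within the scatter, while a 2.5-fold higher number from compound 1 to compound 2 (0.39 log units; beyond the scatter) is the one step among them that reaches beyond it. Compound 4 `O=C(Nc1cccc(OCc2cn(-c3cccc(Br)c3)nn2)c1)Nc1ccc(Cl)c(C(F)(F)F)c1` carries the change (3-bromophenyl in place of 2-chlorophenyl on an aromatic nitrogen), the same kind of aryl exchange on the aromatic nitrogen as in the measured steps. Because a 1.5-fold higher number from compound 1 to compound 3 (0.17 log units; within the scatter) and a 1.7-fold lower number from compound 2 to compound 3 (0.22 log units; within the scatter) both stayed within the scatter, compound 4 is expected to show a step of a 1.0-fold higher number from compound 3 to compound 4 (0.01 log units; within the scatter), that is, none beyond the scatter. Compound 4 is therefore estimated to give about 2000 nM in this assay, within a range from 900 nM to 4500 nM.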

Compound 4, half-maximal inhibitory concentration: 1040 nM
Compound 4: the middle estimate sits 1.9-fold (0.28 log units) above what was measured; the range from low to high includes it.
By their numbers in this assay, from the lowest: compounds 4, 1, 3 and 2 (each within the scatter of the next, the first and the last beyond it).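

In this assay, the exchange of 2-chlorophenyl for 3-bromophenyl on the aromatic nitrogen gives a 1.9-fold lower number from compound 3 to compound 4 (0.28 log units; within the scatter), and the bromo and methoxy compounds also stay close, with a 1.3-fold lower number from compound 1 to compound 4 (0.10 log units; within the scatter). What is new is a second step beyond the scatter at this position, a 3.1-fold lower number from compound 2 to compound 4 (0.49 log units; beyond the scatter), so compound 2 with its isopropyl group now stands apart from both compound 1 and compound 4, although compound 3 still lies within the scatter of compound 2, with a 1.7-fold lower number from compound 2 to compound 3 (0.22 log units; within the scatter). Nothing available explains these differences.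

The exchange from compound 3 to compound 4 alters both the halogen and its place on the ring, so the effects of the two remain unseparated. The compounds shown also leave open how an aryl group carrying an amine or a carboxylic acid, or an unsubstituted phenyl, would read out here.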